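Swapping the Aryl Group at the Carbonyl in Compound 2

The source may hold more compounds than are shown below. What is called first, only, known or untested is meant among the compounds shown, and "the series" means these compounds.

Measured so far:
compound 1 `COc1ccc(C2CC(=NOC(=O)c3ccc(F)cc3)CC(c3ccc(OC)cc3)N2C)cc1` — 152000 nM
compound 2 `COc1ccc(C2CC(=NOC(=O)c3ccc([N+](=O)[O-])cc3)CC(c3ccc(OC)cc3)N2C)cc1` — 280000 nM

Of the compounds shown here, two have been measured in a functional assay, with a stated time of 30 min; a higher number here means a weaker inhibitor, a lower number a stronger inhibitor. Compound 1 gives 152000 nM in this assay. Compound 2 gives 280000 nM, the higher of the two numbers, although the step of a 1.8-fold higher number from compound 1 to compound 2 (0.27 log units; within the scatter) lies within the scatter, so the two cannot be told apart. Compound 3 `COc1ccc(C2CC(=NOC(=O)c3ccccc3O)CC(c3ccc(OC)cc3)N2C)cc1` has not yet been measured; it differs from compound 2 in one place: 2-hydroxyphenyl in place of 4-nitrophenyl on a carbonyl carbon. Going by the values given here, the only measured step that bears on this change, a 1.8-fold higher number from compound 1 to compound 2 (0.27 log units; within the scatter), also replaced a group on the aromatic ring attached to the carbonyl carbon and stayed within the scatter. On that basis no step beyond the scatter is expected in either direction, and the expected step is a 1.3-fold lower number from compound 2 to compound 3 (0.10 log units; within the scatter). Compound 3 is therefore estimated at 220000 nM, with a range from 70000 nM to 700000 nM.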

Compound 3, half-maximal inhibitory concentration: 29000 nM
Compound 3: middle estimate off by 7.6-fold (0.88 log units), on the high side, and the stated range ends above it.
By their numbers in this assay, from the lowest: compound 3; then compounds 1 and 2 (each within the scatter of the next).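

In this assay, this position proves responsive to the aryl group on the carbonyl carbon: 2-hydroxyphenyl in place of 4-nitrophenyl gives a 9.7-fold lower number from compound 2 to compound 3 (0.98 log units; beyond the scatter), and 2-hydroxyphenyl in place of 4-fluorophenyl gives a 5.2-fold lower number from compound 1 to compound 3 (0.72 log units; beyond the scatter), both beyond the scatter. The earlier exchange between 4-fluorophenyl and 4-nitrophenyl could not be told apart, so only the entry of 2-hydroxyphenyl shows that a change here can move the number and yields a stronger inhibitor than either compound 1 or compound 2. Nothing measured here accounts for this shift.

The compounds shown leave open whether the hydroxy group itself matters or whether the result reflects the loss of the fluoro or nitro group. A plain phenyl, or a methoxy group or an amine in place of the hydroxy group, would bear on that question.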